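The source may hold more compounds than are shown below. What is called first, only, known or untested is meant among the compounds shown, and "the series" means these compounds.

In a functional assay on HepG2 cells (Homo sapiens) for inhibition, read by MTT assay, with a stated time of 72 h (a lower number here means a stronger inhibitor, a higher number a weaker inhibitor), compound 2 (`O=[N+]([O-])c1ccc(-c2nnc(SCCCN3CCN(c4nc5ccccc5s4)CC3)o2)cc1`) gives 93300 nM and compound 1 (`Fc1ccc(-c2nnc(SCCCN3CCN(c4nc5ccccc5o4)CC3)o2)cc1`) gives 83800 nM, two values within the usual scatter of each other. Compound 3 (`Fc1ccc(-c2nnc(SCCCN3CCN(c4nc5ccccc5s4)CC3)o2)cc1`) has fluoro in place of nitro on an aromatic carbon of compound 2: fluoro in place of nitro on an aromatic carbon. Among the compounds with values here, no measured pair shows this change, so the expectation rests on compound 2 at 93300 nM, and no step beyond the scatter is expected in this assay. The estimated step of a 1.1-fold lower number from compound 2 to compound 3 (0.04 log units; within the scatter) is expected to stay within that scatter. The expected value for compound 3 is 85000 nM, with an estimated range of 40000 nM to 180000 nM.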

Compound 3, half-maximal inhibitory concentration: 234000 nM
Estimate against measurement, compound 3: 2.8-fold (0.44 log units) below, and the stated range ends below it.
By their numbers in this assay, from the lowest: compounds 1 and 2 (each within the scatter of the next); then compound 3.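

In this assay, the step of a 2.5-fold higher number from compound 2 to compound 3 (0.40 log units; beyond the scatter) shows that the group para to a large group on the aromatic ring matters, with 4-fluorophenyl giving the weaker inhibitor than 4-nitrophenyl. The other end of the molecule matters too: 1,3-benzothiazol-2-yl in place of 1,3-benzoxazol-2-yl gives a 2.8-fold higher number from compound 1 to compound 3 (0.45 log units; beyond the scatter), which compounds 1 and 2, differing in two places, could not reveal. Nothing measured here explains either step.

From the compounds shown here alone, whether the nitro and fluoro step holds with 1,3-benzoxazol-2-yl remains open. So does how a methoxy or nitrile group would compare at that same ring position.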